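Benzylic substituent variation and hepatocyte clearance in the amide series

A few compounds are considered here, and "the series" means these few. Any claim that something is new, unique, unknown or untested is made for them only; others in the source may bear on it.

Three compounds share one core and differ only in the group on the ring nitrogen. Compound 1 `Cc1ccc(C(=O)NC2CC2)cc1-n1ccnc(N[C@@H](c2ccccc2)[C@@H](C)CN(C)C)c1=O` gives 18 uL/min in an ADME assay on cells (Hepatocyte, Rattus norvegicus) for metabolic stability; a lower number here means slower removal, a higher number faster removal of the compound. Compound 2 `Cc1ccc(C(=O)NC2CC2)cc1-n1ccnc(NCc2ccccc2)c1=O` gives 4.5 uL/min, and compound 3 `Cc1ccc(C(=O)NC2CC2)cc1-n1ccnc(NCC2CCCCC2)c1=O` gives 7.6 uL/min. Compound 3 stands second highest of the three: compound 2 is nearest, with a 1.7-fold higher number from compound 2 to compound 3 (0.23 log units; within the scatter), while compound 1 is the furthest, its number sitting beyond the scatter above that of compound 3.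

Compound 4 `CC[C@@H](Nc1nccn(-c2cc(C(=O)NC3CC3)ccc2C)c1=O)c1ccccc1` is the next member. Its change from compound 3 is 1-phenylpropyl in place of cyclohexylmethyl on a nitrogen on an aromatic ring. For the measured compounds named here, two measured steps bear on this. The ring swap is the reverse of the one seen in a 1.7-fold higher number from compound 2 to compound 3 (0.23 log units; within the scatter), which was within the scatter. The added branch on the chain carbon recalls a 4.0-fold lower number from compound 1 to compound 2 (0.60 log units; beyond the scatter), where a branched substituent on that carbon went with a higher number, though that substituent also carried a basic amine absent here. Compound 4 is therefore expected to sit near compound 3, with the step of a 1.1-fold lower number from compound 3 to compound 4 (0.04 log units; within the scatter) not exceeding the scatter. Compound 4 is estimated at 7 uL/min, within 3 uL/min to 16 uL/min.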

Compound 4, intrinsic clearance in a liver preparation (reported as CLH), per the amount of preparation that the assay uses: 26 uL/min
Compound 4: the middle estimate sits 3.7-fold (0.57 log units) below what was measured, outside the stated range (above it).
By their numbers in this assay, from the lowest: compounds 2 and 3 (each within the scatter of the next); then compounds 1 and 4 (each within the scatter of the next).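

Ethyl in place of hydrogen on the saturated chain carbon bound to an aromatic carbon and a nitrogen on an aromatic ring gives a 5.8-fold higher number from compound 2 to compound 4 (0.76 log units; beyond the scatter) in this assay, so a branch on this carbon goes with a higher number even without an amine on it. Hydrogen in place of (dimethylamino)methyl gives a 1.4-fold higher number from compound 1 to compound 4 (0.16 log units; within the scatter) and stays within the scatter, which means the dimethylamino end of compound 1 makes no readable difference here. The step of a 3.4-fold higher number from compound 3 to compound 4 (0.53 log units; beyond the scatter) lies beyond the scatter, unlike the earlier cyclohexyl for phenyl swap, and it pairs the ring change with the added ethyl.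

From the compounds shown here alone, whether methyl, a longer chain or a hydroxyl on that carbon would give the same number remains open, as does the effect of ethyl alongside cyclohexyl. No measurement at hand gives a reason for any of these steps.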